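Benzoyl for Tert-Butoxycarbonyl: Cytotoxicity Notes on Compound 4

A few compounds are considered here, and "the series" means these few. Any claim that something is new, unique, unknown or untested is made for them only; others in the source may bear on it.

Measured compounds:
- compound 1, `CC(=O)c1cccc(Nc2nc(-c3sc(NC(=O)OC(C)(C)C)nc3C)cs2)c1`: 101000 nM
- compound 2, `CC(=O)Nc1nc(C)c(-c2csc(Nc3ccccc3)n2)s1`: "not determined" (no result reported)
- compound 3, `CC(=O)Nc1nc(C)c(-c2csc(Nc3ccc(C(C)=O)cc3)n2)s1`: "not determined" (no result reported)

Among the compounds with values here, in an ADME assay on RD cells (Homo sapiens) for cytotoxicity, read by microscopy (a lower number here means that less compound is tolerated, a higher number that more compound is tolerated), compound 1 gives 101000 nM, the only number in the set. Compound 2 and compound 3 carry no result in this assay, so compound 1 is the sole reference point for the series. Compound 4, `CC(=O)c1cccc(Nc2nc(-c3sc(NC(=O)c4ccccc4)nc3C)cs2)c1`, differs from compound 1 by phenyl in place of tert-butoxy on a carbonyl carbon. Within the data shown here, no measured pair shows what such a change does here, and nothing in the data points in either direction. The step expected in this assay, a 1.3-fold lower number from compound 1 to compound 4 (0.13 log units; within the scatter), is therefore taken as none beyond the scatter. Compound 4 is estimated at 75000 nM, with an expected range from 25000 nM to 160000 nM.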

Compound 4, half-maximal cytotoxic concentration: 11800 nM
The estimate for compound 4 lay 6.4-fold (0.80 log units) above the measured number, and the stated range ends above it.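

Swapping tert-butoxy for phenyl on the carbonyl carbon gives the series its first readable step: this assay shows an 8.6-fold lower number from compound 1 to compound 4 (0.93 log units; beyond the scatter) and so this position is not silent. Benzamido is tolerated at a lower concentration than (tert-butoxycarbonyl)amino, at least in this single pair. No measurement available here accounts for the step.

One pair cannot separate the arrival of the phenyl ring from the loss of tert-butoxy. Going by these compounds, whether cyclohexyl or an amine on the same carbonyl carbon would follow compound 4 or compound 1 remains open.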